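The source may report more compounds than this note shows. Statements on the series, on what has been measured and on what is new or still open speak of the compounds shown alone.

Compound 1 `CCOC(=O)c1ccc(NC(=O)CSC(=S)N[C@H]2CCOC2=O)cc1` gives 21700 nM in a functional assay on MGC-803 cells (Homo sapiens) for cytotoxicity, read by MTT assay, with a stated time of 72 h; on this read-out lower numbers stand for stronger inhibition and higher numbers for weaker inhibition.
Compound 2 `CSC(=S)N[C@H]1CCOC1=O` gives only a limit of the assay, > 128000 nM, not a number.
Compound 3 `CCSC(=S)N[C@H]1CCOC1=O` likewise gives only a limit, > 128000 nM.

Compound 3 therefore stands at the upper edge of what this assay reports, together with compound 2, as the limit of > 128000 nM in this assay, at which 2 of the 3 values shown sit, shows. The step that the two limits leave unreadable from compound 2 to compound 3 is consequently unreadable, since both ends are limits. Among the compounds with values here, compound 1 is the sole compound here with a number, and it carries a much larger substituent on the sulfur.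

Compound 4 `CCCCCCCCSC(=S)N[C@H]1CCOC1=O` differs from compound 3 by hexyl in place of hydrogen on a saturated chain carbon, two bonds along the chain from a sulfur. Within the data shown here, no measured step with a readable size bears on this lengthening of the chain, so no direction beyond the scatter can be expected with confidence. Compound 4 is expected near 100000 nM, within 30000 nM to 300000 nM, an expected step of an at least 1.2-fold lower number from compound 3 to compound 4 (0.10 log units; that floor lies within the scatter), and very possibly again only a limit.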

Compound 4, half-maximal inhibitory concentration: > 128000 nM
Compound 4: no number, only a limit; the forecaster's own chance of this, stated with the estimate: 55%; middle value at least 1.2-fold (0.10 log units) away from the limit.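

Within the data shown here, compound 3 and compound 4 both give only a limit and not a number, so no step between them can be read: the limit of > 128000 nM in this assay, at which 3 of the 4 values shown sit. In this assay, as far as these compounds go, it stays open whether the longer chain of compound 4 changes inhibition at all.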